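A few compounds are considered here, and "the series" means these few. Any claim that something is new, unique, unknown or untested is made for them only; others in the source may bear on it.

In an ADME assay on Vero cells (Chlorocebus sabaeus) for cytotoxicity, read by sulforhodamine B assay, with a stated time of 48 h (a higher number here means that more compound is tolerated, a lower number that less compound is tolerated), compound 1 `O=C(Nc1ccccc1)Nc1ncc([N+](=O)[O-])s1` reads > 1000000 nM and this is a limit of the assay, not a number. Compound 2 `O=C(Nc1ccc(F)cc1)Nc1ncc([N+](=O)[O-])s1` reads > 1000000 nM which is likewise a limit. Compound 3 `COc1ccc(NC(=O)Nc2ncc([N+](=O)[O-])s2)cc1` has "not determined" (no result reported) as its entry, so it holds no place of its own on the scale, and the nearest evidence is the limit of > 1000000 nM in this assay, at which 2 of the 3 values shown sit, for the other two compounds. Compound 4 `CCOc1ccc(NC(=O)Nc2ncc([N+](=O)[O-])s2)cc1` differs from compound 3 through methyl in place of hydrogen on a saturated chain carbon bound to an oxygen on an aromatic ring and the change reads methoxy to ethoxy. Since a step that the two limits leave unreadable from compound 1 to compound 2 gives no size to carry over, no step beyond the scatter is expected in this assay from this change. Compound 4 is estimated at 1000000 nM with an expected range from 250000 nM to 2000000 nM and may well return only a limit.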

Compound 4, half-maximal cytotoxic concentration: > 1000000 nM
Compound 4 gave a limit, no number; the forecaster's own chance of this, stated with the estimate: 65%; the middle value sits exactly at the limit.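

No step can be read between compound 1, compound 2 and compound 4, because each gives only a limit, not a number: the limit of > 1000000 nM in this assay, at which 3 of the 4 values shown sit.

The compounds shown leave open how much of each is tolerated beyond that limit, and whether hydrogen, fluoro or ethoxy on the aromatic carbon changes it.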